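Chlorophenyl to nitrophenyl at the dienone terminus

The source may report more compounds than this note shows. Statements on the series, on what has been measured and on what is new or still open speak of the compounds shown alone.

Of the compounds shown here, two have been read in a functional assay on SMMC-7721 cells (Homo sapiens) for antiproliferative activity, read by MTT assay, with a stated time of 48 h (on this read-out lower numbers stand for stronger inhibition and higher numbers for weaker inhibition), so far. Compound 1 `O=C(/C=C/c1ccc(Oc2cc(=O)oc3ccccc23)cc1)/C=C/c1ccccn1` gives 35400 nM there. Compound 2 `COc1cc(OC)c2c(=O)c(OCCCCOc3ccccc3/C=C/C(=O)/C=C/c3ccc(Cl)cc3)c(-c3cc(OC)c(OC)c(OC)c3)oc2c1` gives 41700 nM in this assay. On these two numbers compound 2 lies within the scatter of compound 1, so no order between them can be stated. Compound 3 `COc1cc(OC)c2c(=O)c(OCCCCOc3ccccc3/C=C/C(=O)/C=C/c3cccc([N+](=O)[O-])c3)c(-c3cc(OC)c(OC)c(OC)c3)oc2c1` is not yet measured in this assay. It differs from compound 2 in one place: 3-nitrophenyl in place of 4-chlorophenyl on a double-bonded chain carbon bound to a double-bonded chain carbon. Among the measured compounds shown here, no step of this kind has been measured, and the two numbers in hand give no lead in either direction for such a change. The expected step is therefore none beyond the scatter, with equal room on either side. For compound 3 the expected value in this assay is 40000 nM, with a range from 15000 nM to 100000 nM, which corresponds to an expected step of a 1.0-fold lower number from compound 2 to compound 3 (0.02 log units; within the scatter).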

Compound 3, half-maximal inhibitory concentration: 7310 nM
For compound 3 the middle estimate is 5.5-fold (0.74 log units) above the measured one; measured number outside the range, below it.
By their numbers in this assay, from the lowest: compound 3; then compounds 1 and 2 (each within the scatter of the next).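

In this assay, 3-nitrophenyl in place of 4-chlorophenyl on a double-bonded chain carbon bound to a double-bonded chain carbon gives a 5.7-fold lower number from compound 2 to compound 3 (0.76 log units; beyond the scatter) and places compound 3 clear of the other two compounds. Among the compounds shown here, this is the first single-place step read, and it shows that this position is not indifferent: with the rest of compound 2 held fixed, the aryl group at this end of the chain alone moves the number beyond the scatter. No measurement in hand bears on why this change has that effect.

The step replaces both the substituent and its ring position in one move, so the contribution of each remains unresolved. Compounds carrying 4-nitrophenyl or 3-chlorophenyl at this position would separate the two, and an amine such as 3-aminophenyl would test whether the nitro group itself is needed.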